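Cyclohexyl on the aromatic nitrogen of compound 2

This account rests on a few compounds, and the source may have more. Where it says the series, first, only, none or still open, it means among the compounds named here.

Values in a functional assay on MCF7 cells (Homo sapiens) for inhibition, read by MTT assay, with a stated time of 5 days; a higher number here means a weaker inhibitor, a lower number a stronger inhibitor:
compound 1 `Cc1cc(Nc2nc(NCc3ccccc3F)nc3[nH]ncc23)n[nH]1` gives 2310 nM
compound 2 `Cc1cc(Nc2nc(NCc3ccc(F)cc3F)nc3[nH]ncc23)n[nH]1` gives 670 nM
compound 3 `Cc1cc(Nc2nc(NCc3ccc(C#N)cc3)nc3[nH]ncc23)n[nH]1` gives 6060 nM

The lowest number of the three belongs to compound 2. The gaps to the others are a 3.4-fold lower number from compound 1 to compound 2 (0.54 log units; beyond the scatter) and a 9.0-fold higher number from compound 2 to compound 3 (0.96 log units; beyond the scatter). Compound 4 `Cc1cc(Nc2nc(NCc3ccc(F)cc3F)nc3c2cnn3C2CCCCC2)n[nH]1` is unmeasured and differs from compound 2 as follows: cyclohexyl in place of hydrogen on an aromatic nitrogen. For the measured compounds named here, no measured step touches this aromatic nitrogen, since all three alter only the aromatic ring on the saturated chain carbon. They serve only as a gauge of size, the largest being a 9.0-fold higher number from compound 2 to compound 3 (0.96 log units; beyond the scatter). A modest rise in this assay is expected, with the direction poorly supported. The expected change is a 2.2-fold higher number from compound 2 to compound 4 (0.35 log units; beyond the scatter). For compound 4 the estimated value is 1500 nM, with an expected range of 300 nM to 8000 nM.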

Compound 4, half-maximal inhibitory concentration: 810 nM
The estimate for compound 4 lay 1.9-fold (0.27 log units) above the measured number, within the range that was stated.
By their numbers in this assay, from the lowest: compounds 2 and 4 (each within the scatter of the next); then compound 1; then compound 3.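

In this assay, for the compounds shown here, cyclohexyl in place of hydrogen on the aromatic nitrogen gives a 1.2-fold higher number from compound 2 to compound 4 (0.08 log units; within the scatter), so this position, untouched by the earlier steps, accepts a large carbon ring without a step beyond the scatter. The hydrogen on this nitrogen is therefore not needed for activity in this pair, the only one that tests it. Nothing available explains this result. As far as these compounds go, whether methyl, or a chain ending in an amine or a carboxylic acid, is accepted on this nitrogen stays open. So does whether cyclohexyl there is equally accepted alongside the 4-cyanophenyl group of compound 3.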